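The compounds below may be only part of what the source reports. "The series", "measured", "known", "first", "only" and "open" are said of these compounds alone.

Measured in a toxicity assay on EA.hy 926 cells (Homo sapiens) for cytotoxicity, read by MTT assay, with a stated time of 48 h; a higher number here means a weaker inhibitor, a lower number a stronger inhibitor:
- compound 1 `COc1cc(/C=C/C(=O)/C=C(/C=C/c2ccc(O)c(OC)c2)NCCO)ccc1O`: > 100000 nM, a limit of the assay
- compound 2 `O=C(/C=C(/C=C/c1ccc(O)cc1)NCCCO)/C=C/c1ccc(O)cc1`: 57300 nM
- compound 3 `COCCNC(=C\C(=O)/C=C/c1ccc(O)c(OC)c1)/C=C/c1ccc(O)c(OC)c1`: >= 100000 nM, a limit of the assay

Among the compounds with values here, compound 2 holds the only actual number here, 57300 nM. Compound 4 `O=C(/C=C(/C=C/c1ccc(O)cc1)NCCO)/C=C/c1ccc(O)cc1` has hydroxy in place of hydroxymethyl on a saturated chain carbon, two bonds along the chain from an amine nitrogen, so 3-hydroxypropyl becomes 2-hydroxyethyl: hydroxy in place of hydroxymethyl on a saturated chain carbon, two bonds along the chain from an amine nitrogen. Within the data shown here, the one measured step, a step that the two limits leave unreadable from compound 1 to compound 3, changes a different part of the chain and gives no size to carry over. Nothing measured therefore points to a shift in this assay, and the expected result is a 1.1-fold higher number from compound 2 to compound 4 (0.05 log units; within the scatter), no step beyond the scatter. For compound 4 the estimate is 65000 nM, with an expected range from 30000 nM to 130000 nM.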

Compound 4, half-maximal inhibitory concentration: 50200 nM
For compound 4 the middle estimate is 1.3-fold (0.11 log units) above the measured one; measured number inside the range.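

Replacing 3-hydroxypropyl with 2-hydroxyethyl gives a 1.1-fold lower number from compound 2 to compound 4 (0.06 log units; within the scatter) in this assay, so the two compounds cannot be told apart. Within the data shown here, this is the first change to this side chain with a readable size, as compound 1 and compound 3 stand at limits and their step cannot be read. Nothing measured here explains why the two chains read alike.

As far as these compounds go, whether a longer chain such as 4-hydroxybutyl would shift the number remains open. So does the effect of an amine or a carboxylic acid in place of the hydroxy.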